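A Dichlorophenyl Outlier and a Dimethoxy Change

The compounds below may be only part of what the source reports. "The series", "measured", "known", "first", "only" and "open" are said of these compounds alone.

Of the compounds shown here, three built on a shared core have been measured in a functional assay on HL-60 cells (Homo sapiens) for antiproliferative activity, with a stated time of 72 h; on this read-out higher numbers stand for weaker inhibition and lower numbers for stronger inhibition. Compound 1 (`OC[C@H]1O[C@@H](n2cnc3c(NCc4ccccc4Br)ncnc32)[C@H](O)[C@@H]1O`) gives 6600 nM, and compound 2 (`COc1cccc(CNc2ncnc3c2ncn3[C@@H]2O[C@H](CO)[C@@H](O)[C@H]2O)c1`) gives 4900 nM. Compound 3 (`OC[C@H]1O[C@@H](n2cnc3c(NCc4ccc(Cl)cc4Cl)ncnc32)[C@H](O)[C@@H]1O`) gives 96300 nM, the highest number of the three and so the weakest inhibition in this small set. Compound 4 (`COc1cccc(CNc2ncnc3c2ncn3[C@@H]2O[C@H](CO)[C@@H](O)[C@H]2O)c1OC`) has yet to be measured. It differs from compound 3 as follows: 2,3-dimethoxyphenyl in place of 2,4-dichlorophenyl on a saturated chain carbon bound to a nitrogen on an aromatic ring. In words, 2,3-dimethoxyphenyl stands in place of 2,4-dichlorophenyl on a saturated chain carbon bound to a nitrogen on an aromatic ring.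

Going by the values given here, three measured steps bear on this change, all at the same place. The step of a 1.3-fold lower number from compound 1 to compound 2 (0.13 log units; within the scatter) stays within the scatter, whereas a 15-fold higher number from compound 1 to compound 3 (1.16 log units; beyond the scatter) and a 20-fold higher number from compound 2 to compound 3 (1.29 log units; beyond the scatter) are both large. The last is the closest guide when read in reverse, as compound 2 also carries a methoxy group. Among the compounds with values here, no measured compound carries two methoxy groups, so the effect of the second one remains unknown. A large step is therefore expected, toward a lower number and beyond the scatter, with a 12-fold lower number from compound 3 to compound 4 (1.08 log units; beyond the scatter) as the estimate. The estimated value for compound 4 is 8000 nM, with an expected range of 2500 nM to 30000 nM.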

Compound 4, half-maximal inhibitory concentration: > 166000 nM
Compound 4 was reported as a limit; the forecaster's own chance of this, stated with the estimate: 8%; middle value at least 20-fold (1.31 log units) away from the limit.
By their numbers in this assay, from the lowest: compounds 2 and 1 (each within the scatter of the next); then compound 3. At a limit, above all of these: compound 4.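

this assay reports compound 4 only as a limit, not as a number: the limit of > 166000 nM in this assay, at which 1 of the 4 values shown sits. Adding one methoxy in place of hydrogen on an aromatic carbon gives an at least 33-fold higher number from compound 2 to compound 4 (1.52 log units; beyond the scatter), and the exchange of 2-bromophenyl for 2,3-dimethoxyphenyl gives an at least 25-fold higher number from compound 1 to compound 4 (1.40 log units; beyond the scatter), so this position, where 2-bromophenyl and 3-methoxyphenyl had read alike, proves far less forgiving of a further methoxy than those earlier values suggested. The remaining step, an at least 1.7-fold higher number from compound 3 to compound 4 (0.23 log units; that floor lies within the scatter), offers only a floor, yet among these four compounds the two phenyl groups with two substituents, 2,4-dichlorophenyl and 2,3-dimethoxyphenyl, both sit at the high end of the numbers, and none of the four goes against that.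

As far as these compounds go, how far compound 4 lies beyond its limit, and so how large the gap to compound 3 really is, stays open. Also open, from the compounds shown here alone, is whether the second methoxy itself matters or merely any second group on the ring, which a hydroxy group or a dimethylamino group at that place could help to separate.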